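The source may report more compounds than this note shows. Statements on the series, on what has been measured and on what is new or still open speak of the compounds shown alone.

Compound 1 `Cc1ccc(C(=O)Nc2cc(Cl)ccc2OCC(=O)Nc2ccc(S(N)(=O)=O)cc2C)cc1`, compound 2 `Cc1cc(S(N)(=O)=O)ccc1NC(=O)COc1ccc(Cl)cc1NC(=O)c1cccc(Cl)c1` and compound 3 `Cc1cc(S(N)(=O)=O)ccc1NC(=O)COc1ccc(Cl)cc1NC(=O)c1cccc(C(F)(F)F)c1` share one core and differ only in the ring attached to a carbonyl carbon. In a functional assay on C8166 cells (Homo sapiens) for cytotoxicity, read by MTT assay (on this read-out lower numbers stand for higher toxicity in this test and higher numbers for lower toxicity in this test), compound 1 gives 54200 nM, compound 2 gives 59700 nM, and compound 3 gives 124000 nM, the highest of the three numbers. Compound 4 `Cc1ccc(C(=O)Nc2cc(Cl)ccc2OCC(=O)Nc2ccc(S(N)(=O)=O)cc2C)cc1C` is the next step from compound 3: 3,4-dimethylphenyl in place of 3-(trifluoromethyl)phenyl on a carbonyl carbon. Among the measured compounds shown here, two measured steps bear on it. a 2.3-fold higher number from compound 1 to compound 3 (0.36 log units; beyond the scatter), and a 2.1-fold higher number from compound 2 to compound 3 (0.32 log units; beyond the scatter), so the trifluoromethyl-bearing ring carried the highest number, while compound 4 returns to a methyl-bearing ring close to that of compound 1. A modest step back toward the number of compound 1 is therefore expected, a 2.1-fold lower number from compound 3 to compound 4 (0.32 log units; beyond the scatter). Compound 4 is estimated at 60000 nM, with a range from 30000 nM to 120000 nM.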

Compound 4, half-maximal cytotoxic concentration: 84100 nM
Beside the measured number, compound 4's estimate is 1.4-fold (0.15 log units) below it; measured number inside the range.
By their numbers in this assay, from the lowest: compounds 1, 2, 4 and 3 (each within the scatter of the next, the first and the last beyond it).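

In this assay the 3,4-dimethylphenyl ring cannot be told apart from the other rings on this carbonyl carbon: the change from 3-(trifluoromethyl)phenyl gives a 1.5-fold lower number from compound 3 to compound 4 (0.17 log units; within the scatter) and the change from 3-chlorophenyl gives a 1.4-fold higher number from compound 2 to compound 4 (0.15 log units; within the scatter). Adding one methyl to the ring of compound 1 likewise gives a 1.6-fold higher number from compound 1 to compound 4 (0.19 log units; within the scatter), so this extra methyl leaves the number within the scatter. Nothing shown here accounts for these steps. From the compounds shown here alone, whether an amine or a carboxylic acid on this ring would give a step beyond the scatter stays open.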